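Pyrimidinyl amide from an ethylphenyl anilide

The source may report more compounds than this note shows. Statements on the series, on what has been measured and on what is new or still open speak of the compounds shown alone.

For the measured compounds named here, compound 1 `CCc1cccc(NC(=O)CN2CCN(c3ccccn3)CC2)c1` is the only member of this small set for which a number is reported: in an assay on cells for agonist activity at D(4) dopamine receptor (Homo sapiens), read by luminescence and beta-arrestin recruitment, with a stated time of 90 min (on this read-out higher numbers stand for an effect only at larger amounts of compound and lower numbers for an effect already at smaller amounts), compound 1 gives 133 nM. Two neighbours carry no number. Compound 2 `Cc1cccc(NC(=O)CCN2CCN(c3ccccn3)CC2)c1`, with a longer linker between the amide and the ring nitrogen, is reported in this assay as "not active" (no number reported). Compound 3 `CCc1cccc(NC(=O)CN2CCN(c3ccc(Cl)cn3)CC2)c1`, with a chlorine on the pyridine ring, is reported in this assay as "not active" (no number reported). So compound 1 stands alone at the top of what can be measured, and the two altered versions around it fell out of the measurable range.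

Compound 4 `O=C(CN1CCN(c2ccccn2)CC1)Nc1cncnc1` changes compound 1 at the other end of the molecule: pyrimidin-5-yl in place of 3-ethylphenyl on an amide-type nitrogen. Going by the values given here, no step of this kind has been measured, so the direction must be guessed. Given that the two nearby changes in compound 2 and compound 3 removed all measurable activity, the estimate for compound 4 is a clear loss, well beyond the usual scatter, and the step from compound 1 to compound 4 is expected to be a 19-fold higher number from compound 1 to compound 4 (1.27 log units; beyond the scatter). In this assay compound 4 is therefore expected to reach about 2500 nM, with a range from 500 nM to 20000 nM, and a real chance that only a limit is reported.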

Compound 4, half-maximal effective concentration: "not active" (no number reported)
For compound 4 the study gives words and no number; there is nothing to compare the estimate with.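

In this assay, for the compounds shown here, compound 1 gives 133 nM but compound 4 carries words and no number, so no step between compound 1 and compound 4 can be read. Nothing measured here bears on this result. The compounds shown leave open how far pyrimidin-5-yl in place of 3-ethylphenyl moves the read-out.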